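This account rests on a few compounds, and the source may have more. Where it says the series, first, only, none or still open, it means among the compounds named here.

Measured compounds: compound 1 `CCc1ccc(NC(=O)N[C@@H](C)c2ccccc2)cc1` with 91%, compound 2 `C[C@H](NC(=O)Nc1ccc(Br)cc1)c1ccccc1` with 96%, and compound 3 `C[C@@H](NC(=O)Nc1ccc(I)cc1)c1ccccc1` with 85%, all in an ADME assay on the whole organism with Oryza sativa as the target, tested at 10 uM; on this read-out higher numbers stand for a weaker effect at the one concentration tested and lower numbers for a stronger effect.

Compound 3 stands at the low end of these three numbers: its gap to compound 1 lies within the scatter, while its gap to compound 2 lies beyond it. Within the data shown here, the only measured step, a number 5 percentage points higher from compound 1 to compound 2 (within the scatter), concerns a change on the aromatic ring and says nothing about configuration.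

Compound 4 `C[C@H](NC(=O)Nc1ccc(I)cc1)c1ccccc1` differs from compound 3 only in this way: the two compounds have the same atoms and bonds and differ only in configuration as drawn: 1 of 1 stereo elements differ; a stereocentre at a saturated chain carbon is drawn R in compound 3 and S in compound 4. Among the measured compounds shown here, no measured pair shows what such an inversion does here, so compound 4 is expected to move by a number 1 percentage points higher from compound 3 to compound 4 (within the scatter), which is no step beyond the scatter. Compound 4 is therefore estimated at 86%, between 72% and 99%.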

Compound 4, a percentage reported as activity, at one concentration (the size of the read-out at that concentration, not a potency): 95%
Compound 4: middle estimate off by 9 percentage points, on the low side, within the range that was stated.
By their numbers in this assay, from the lowest: compounds 3, 1, 4 and 2 (each within the scatter of the next, the first and the last beyond it).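

In this assay, among these compounds, the inversion at the saturated chain carbon gives the first reading on configuration, a number 10 percentage points higher from compound 3 to compound 4 (within the scatter), so it shows no step beyond the scatter. This reading concerns the stereocentre alone: the fact that compounds 3 and 4 differ only in the configuration as drawn. Changing the group on the aromatic carbon likewise shows no step beyond the scatter, with a number 1 percentage points lower from compound 2 to compound 4 (within the scatter) and a number 4 percentage points higher from compound 1 to compound 4 (within the scatter).

As far as these compounds go, it remains open whether the same inversion would read alike with bromo or ethyl on the aromatic carbon. Also open, from the compounds shown here alone, is what an amine or a carboxylic acid at that carbon would give.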